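The source may report more compounds than this note shows. Statements on the series, on what has been measured and on what is new or still open speak of the compounds shown alone.

In an ADME assay on microsomes from liver (Homo sapiens) for metabolic stability, read by LC-MS, using NADPH, tested at 5 uM (on this read-out higher numbers stand for a longer-lived compound and lower numbers for a shorter-lived compound), the three measured compounds stand as follows:
compound 1 `Cc1cc(S(=O)(=O)/N=C(\N)N/N=C/C#Cc2ccccc2)c(SCc2ccccc2C(F)(F)F)cc1Cl` gives 0.653 h;
compound 2 `C/C(C#Cc1ccccc1)=N\N/C(N)=N/S(=O)(=O)c1cc(C)c(Cl)cc1SCc1ccccc1C(F)(F)F` gives 0.107 h;
compound 3 `Cc1cc(S(=O)(=O)/N=C(\N)N/N=C/C#Cc2ccccc2)c(SCc2ccccc2Cl)cc1Cl` gives 0.254 h.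

Compound 3 differs from compound 1 by chloro in place of trifluoromethyl on an aromatic carbon; the step of a 2.6-fold lower number from compound 1 to compound 3 (0.41 log units; beyond the scatter). Compound 2 differs from compound 1 by a group of 11 heavy atoms (10 carbon, 1 nitrogen; one six-membered aromatic ring of carbon only) in place of a group of 10 heavy atoms (9 carbon, 1 nitrogen; one six-membered aromatic ring of carbon only), on an amine nitrogen, and that step ran a 6.1-fold lower number from compound 1 to compound 2 (0.79 log units; beyond the scatter).

Compound 4 `C/C(C#Cc1ccccc1)=N\N/C(N)=N/S(=O)(=O)c1cc(C)c(Cl)cc1SCc1ccccc1Cl` has not yet been measured in this assay. It differs from compound 3 by a group of 11 heavy atoms (10 carbon, 1 nitrogen; one six-membered aromatic ring of carbon only) in place of a group of 10 heavy atoms (9 carbon, 1 nitrogen; one six-membered aromatic ring of carbon only), on an amine nitrogen. The surroundings of the place are the same in both pairs, so this is the same change that turned compound 1 into compound 2.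

Compound 4 is therefore expected to come out near 0.045 h, most likely between 0.02 h and 0.12 h. That estimate means a step of a 5.6-fold lower number from compound 3 to compound 4 (0.75 log units; beyond the scatter), and it rests on the measured step of a 6.1-fold lower number from compound 1 to compound 2 (0.79 log units; beyond the scatter) applied to the value of compound 3, 0.254 h.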

Compound 4, half-life: 1.42 h
Compound 4: the middle estimate sits 32-fold (1.50 log units) below what was measured; the measured number lies above the stated range.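

In this assay, placing the group of 11 heavy atoms on the amine nitrogen gave a 5.6-fold higher number from compound 3 to compound 4 (0.75 log units; beyond the scatter) in the chloro series, so the change did not carry over from one core to the other, and even its direction reversed: the same change on two cores in this assay, a 6.1-fold lower number (0.79 log units; beyond the scatter) from compound 1 to compound 2 and a 5.6-fold higher number (0.75 log units; beyond the scatter) from compound 3 to compound 4, 34-fold (1.53 log units) apart, beyond the scatter of two such steps. The swap to chloro from trifluoromethyl also did not carry over unchanged, giving a 13-fold higher number from compound 2 to compound 4 (1.12 log units; beyond the scatter) on the other core: the same change on two cores in this assay, a 2.6-fold lower number (0.41 log units; beyond the scatter) from compound 1 to compound 3 and a 13-fold higher number (1.12 log units; beyond the scatter) from compound 2 to compound 4, 34-fold (1.53 log units) apart, beyond the scatter of two such steps. These four compounds show that the outcome of each change depends on the other, but they do not show why, and one pair per core gives no general rule.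

The compounds shown leave open what a fluoro or methoxy group would do in place of chloro and trifluoromethyl. They also leave open whether a longer chain in the group on the amine nitrogen would follow compound 2 or compound 4.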